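Carbamate to urea at the aminomethyl side chain

The source may report more compounds than this note shows. Statements on the series, on what has been measured and on what is new or still open speak of the compounds shown alone.

Measured so far:
compound 1, `CCCCc1ccc(CNC(=O)OC(C)(C)C)c(=O)n1Cc1ccc(-c2ccccc2-c2nn[nH]n2)cc1`: 10 nM
compound 2, `CCCCc1ccc(CN)c(=O)n1Cc1ccc(-c2ccccc2-c2nn[nH]n2)cc1`: 20 nM

In a functional assay (aorta) for antagonist activity, with Oryctolagus cuniculus as the target (on this read-out lower numbers stand for stronger inhibition and higher numbers for weaker inhibition), compound 1 gives 10 nM, the lower of the two numbers in hand. Compound 2 gives 20 nM, and the step of a 2.0-fold higher number from compound 1 to compound 2 (0.30 log units; within the scatter) is within the scatter, so the two compounds are not told apart.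

Compound 3, `CCCCNC(=O)NCc1ccc(CCCC)n(Cc2ccc(-c3ccccc3-c3nn[nH]n3)cc2)c1=O`, is not yet measured. It differs from compound 1 by butylamino in place of tert-butoxy on a carbonyl carbon. Going by the values given here, the only measured step, a 2.0-fold higher number from compound 1 to compound 2 (0.30 log units; within the scatter), removes the whole tert-butoxycarbonyl group; it says nothing about replacing tert-butoxy while the carbonyl and the amide-type nitrogen stay, and no measured pair shows such a change. Compound 3 is therefore expected to stay close to compound 1, with the step of no change at the digits printed from compound 1 to compound 3 (within the scatter) expected to lie within the scatter. Compound 3 is estimated at 10 nM, within 3 nM to 30 nM, in this assay.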

Compound 3, half-maximal inhibitory concentration: 10 nM
For compound 3 middle estimate and measured number coincide at the digits printed; low and high end bracket the measured number.
By their numbers in this assay, from the lowest: compounds 1, 3 and 2 (each within the scatter of the next).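

In this assay, butylamino in place of tert-butoxy on the carbonyl carbon turns the carbamate into a urea while the carbonyl and the amide-type nitrogen stay, and the step reads no change at the digits printed from compound 1 to compound 3 (within the scatter). Going by these compounds alone, this is the first reading of a replacement at that carbonyl carbon, rather than removal of the whole group, and it does not separate the two compounds. Butylcarbamoyl in place of hydrogen on the amine nitrogen gives a 2.0-fold lower number from compound 2 to compound 3 (0.30 log units; within the scatter), so the free amine, the carbamate and the urea cannot be told apart here, and no measurement on hand offers an explanation for this.

Open, on these data alone, is whether a benzoyl group, an acetyl group or a sulfonyl group on this amine nitrogen would stay within the same range. Also open, as far as these compounds go, is whether a longer chain or a phenyl ring in place of the butyl of the urea would move the number beyond the scatter.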